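The source may report more compounds than this note shows. Statements on the series, on what has been measured and on what is new or still open speak of the compounds shown alone.

Of the compounds shown here, three have been measured in an assay on CHO cells for displacement of a labelled ligand from adenosine receptor A3 (Homo sapiens), read by scintillation counting, tested at 1 uM; on this read-out lower numbers stand for less inhibition and higher numbers for more inhibition at the one concentration tested (going by the name of the read-out). Compound 1 `CC(C)c1nc(N)c2nn(-c3ccccc3)cc2n1` gives 11%, the lowest of the three numbers. Compound 2 `COc1ccc(Cc2nc(N)c3nn(-c4ccccc4)cc3n2)cc1` gives 38% in this assay, and compound 3 `Nc1nc(Cc2cccc(C(F)(F)F)c2)nc2cn(-c3ccccc3)nc12` gives 41% in this assay; both stand above compound 1 by more than the scatter, while compounds 2 and 3 lie within the scatter of each other. Among the compounds with values here, no two measured compounds differ in only one place, so no single-point step can be read off.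

Compound 4 `Nc1nc(Cc2ccc(Cl)cc2)nc2cn(-c3ccccc3)nc12` has not been measured. It differs from compound 1 by 4-chlorobenzyl in place of isopropyl on an aromatic carbon. Compounds 2 and 3, which also replace the isopropyl of compound 1 with a larger group at the same place, give markedly higher inhibition than compound 1, and compound 4 is expected to follow them. The step from compound 1 to compound 4 in this assay is expected to be a number 29 percentage points higher from compound 1 to compound 4 (beyond the scatter), upward and beyond the scatter. Compound 4 is therefore estimated at 40% in this assay, with a range from 22% to 58%.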

Compound 4, a percentage reported as inhibition, at one concentration (the size of the read-out at that concentration, not a potency): 11%
For compound 4 the middle estimate is 29 percentage points above the measured one, and the stated range ends above it.
By their numbers in this assay, from the lowest: compounds 1 and 4 (each within the scatter of the next); then compounds 2 and 3 (each within the scatter of the next).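

In this assay, a larger group with an aromatic ring at this carbon does not by itself raise the number: 4-chlorobenzyl in place of isopropyl gives no change at the digits printed from compound 1 to compound 4 (within the scatter) and so matches the small alkyl group. What changes the read-out here is the substituent carried on the benzyl group, since chloro in place of methoxy on its aromatic carbon gives a number 27 percentage points lower from compound 2 to compound 4 (beyond the scatter) and shows that the benzyl group alone is not enough for the higher number. Nothing available on these compounds accounts for this difference between chloro and methoxy.

On these data alone, whether an amine or a carboxylic acid on the benzyl group would stand with methoxy or with chloro remains open. Also open, as far as these compounds go, is whether a longer alkyl chain in place of isopropyl would differ from compound 1 at the one concentration tested.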